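Isopropyl Sulfone Replaces Cyclobutyl in a Weak Series

The source may hold more compounds than are shown below. What is called first, only, known or untested is meant among the compounds shown, and "the series" means these compounds.

Compound 3 `O=C([C@@H]1CCCN(S(=O)(=O)c2ccc(S(=O)(=O)C3CCC3)cc2)C1)N1CCC(F)(F)CC1` reaches only a limit in a functional assay on MIA PaCa-2 cells (Homo sapiens) for inhibition, read by MTT assay, with a stated time of 3 days (a higher number here means a weaker inhibitor, a lower number a stronger inhibitor), where compound 3 gives > 3000 nM. Compound 1 `O=C([C@@H]1CCCN(S(=O)(=O)c2ccc(S(=O)(=O)N3CC[C@@H](O)C3)cc2)C1)N1CCC(F)(F)CC1` likewise gives only a limit in this assay, > 3000 nM. Compound 2 `CCN(CC)S(=O)(=O)c1ccc(S(=O)(=O)N2CCC[C@@H](C(=O)N3CCC(O)CC3)C2)cc1` also gives a limit in this assay, > 10000 nM. Since the numbers shown consist of the limit of > 3000 nM in this assay, at which 2 of the 3 values shown sit, and (the limit of > 10000 nM in this assay, at which 1 of the 3 values shown sits), no measured step has a readable size, and the step that the two limits leave unreadable from compound 1 to compound 3 stays unreadable. Compound 4 `CC(C)S(=O)(=O)c1ccc(S(=O)(=O)N2CCC[C@@H](C(=O)N3CCC(F)(F)CC3)C2)cc1` differs from compound 3 by isopropyl in place of cyclobutyl on a sulfonyl sulfur. Among the compounds with values here, no measured step bears on this change, so nothing points to a shift beyond the scatter, and the step that the limit leaves unreadable from compound 3 to compound 4 is expected to be small. Compound 4 is expected to give about 10000 nM in this assay, within 3000 nM to 40000 nM, most likely again reported only as a limit.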

Compound 4, half-maximal inhibitory concentration: > 3000 nM
Compound 4: only a limit was reported (the forecaster's own chance of this, stated with the estimate: 80%); the middle value lies beyond the limit too.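

Compound 1, compound 3 and compound 4 are all reported only as limits in this assay, so the steps to compound 4 cannot be read. The compounds shown leave open whether isopropyl and cyclobutyl on a sulfonyl sulfur differ at all in this assay.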